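Shortening the ether chain on a bromophenyl sulfonylurea

This account rests on a few compounds, and the source may have more. Where it says the series, first, only, none or still open, it means among the compounds named here.

Three compounds share a core and were tested in a functional assay on thoracic aorta (Rattus norvegicus, strain Wistar), with a stated time of 15 min; a higher number here means that more compound is needed for the effect, a lower number that less compound is needed. Compound 3 `CC(NC(=O)NS(=O)(=O)c1ccccc1)c1cc(Br)ccc1OCc1ccccc1` gives 130000 nM, the lowest of the two numbers recorded; its nearest neighbour is compound 1 `CC(C)Oc1ccc(Br)cc1C(C)NC(=O)NS(=O)(=O)c1ccccc1` with 143000 nM, within the scatter. Compound 2 `CCOc1ccc(F)cc1C(C)NC(=O)NS(=O)(=O)c1ccccc1` returns only a limit, > 300000 nM. The step of a 1.1-fold lower number from compound 1 to compound 3 (0.04 log units; within the scatter) shows that changing the alkoxy group barely moves this assay. Compound 4 `CCOc1ccc(Br)cc1C(C)NC(=O)NS(=O)(=O)c1ccccc1` differs from compound 3 by methyl in place of phenyl on a saturated chain carbon bound to an oxygen on an aromatic ring. Among the compounds with values here, since the only measured step along this ether, a 1.1-fold lower number from compound 1 to compound 3 (0.04 log units; within the scatter), lay within the scatter, no step beyond the scatter is expected from compound 3 to compound 4, with a little room upward because compound 2 sits at the limit of > 300000 nM in this assay, at which 1 of the 3 values shown sits. Compound 4 is therefore estimated at 170000 nM, between 80000 nM and 350000 nM, a step of a 1.3-fold higher number from compound 3 to compound 4 (0.12 log units; within the scatter).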

Compound 4, half-maximal effective concentration: > 300000 nM
Compound 4: no number, only a limit; the forecaster's own chance of this, stated with the estimate: 35%; at least 1.7-fold (0.24 log units) between middle value and limit.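

In this assay, the ether position proves less indifferent than the earlier step suggested: methyl in place of phenyl gives an at least 2.3-fold higher number from compound 3 to compound 4 (0.36 log units; beyond the scatter), and the comparison with the isopropyl ether gives an at least 2.0-fold higher number from compound 1 to compound 4 (0.32 log units; beyond the scatter). Ethoxy thus stands apart from both the benzyl and the isopropyl ethers on the bromo compounds. Compound 2 and compound 4 both stand at a limit, so the step between them cannot be read: the limit of > 300000 nM in this assay, at which 2 of the 4 values shown sit.

From the compounds shown here alone, how far compound 4 lies past its limit remains open. So does whether a longer chain, such as butyl, or a terminal amine on this ether would return a number.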